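A few compounds are considered here, and "the series" means these few. Any claim that something is new, unique, unknown or untested is made for them only; others in the source may bear on it.

Compound 1 `O=C(N[C@@H]1[C@H](O)[C@@H](CO)O[C@H]1n1cnc2c(NCc3cccc4ccccc34)ncnc21)c1cc(Cl)cc(Cl)c1` gives 35 uM 
Compound 2 `O=C(N[C@@H]1[C@H](O)[C@@H](CO)O[C@H]1n1cnc2c(NCc3cc(O)cc4ccccc34)ncnc21)c1cc(Cl)cc(Cl)c1` gives 43 uM 

Both numbers come from a functional assay on NIH3T3 cells (Mus musculus) (on this read-out higher numbers stand for an effect only at larger amounts of compound and lower numbers for an effect already at smaller amounts), and they lie within the scatter of each other, so compound 2 stands level with compound 1 and nothing separates the pair.

Compound 3 `COc1cc(CNc2ncnc3c2ncn3[C@@H]2O[C@H](CO)[C@@H](O)[C@H]2NC(=O)c2cc(Cl)cc(Cl)c2)c2ccccc2c1` alters the hydroxy group of compound 2 (methyl in place of hydrogen on an oxygen on an aromatic ring). This places methyl in place of hydrogen on an oxygen on an aromatic ring, so hydroxy becomes methoxy.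

Among the compounds with values here, no measured pair shows this exact change. Within the data shown here, the closest guide is the single step that introduced the hydroxy group, a 1.2-fold higher number from compound 1 to compound 2 (0.09 log units; within the scatter) and it did not move the number beyond the scatter. One small step is thin evidence, and it says nothing directly about a methyl on that oxygen. Even so, it gives no reason to expect a shift in either direction. The expected step is a 1.1-fold lower number from compound 2 to compound 3 (0.03 log units; within the scatter) and so no change beyond the scatter is expected. In this assay the estimated value for compound 3 is 40 uM with an expected range from 15 uM to 100 uM on this estimate.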

Compound 3, concentration for half-maximal effect: 32 uM
Beside the measured number, compound 3's estimate is 1.3-fold (0.10 log units) above it; the measured number falls inside the stated range.
By their numbers in this assay, from the lowest: compounds 3, 1 and 2 (each within the scatter of the next).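

In this assay, placing a methyl on the oxygen gives a 1.3-fold lower number from compound 2 to compound 3 (0.13 log units; within the scatter), so changing 3-hydroxynaphthalen-1-yl to 3-methoxynaphthalen-1-yl does not separate the pair. Within the data shown here, this is the first sign that the hydrogen on this oxygen can be replaced by a small carbon group without a change beyond the scatter. Set against the parent without any group there, the methoxy group gives a 1.1-fold lower number from compound 1 to compound 3 (0.04 log units; within the scatter), so hydrogen, hydroxy and methoxy at this position all stand level, and the data offer nothing that explains this lack of separation.

Going by these compounds, the three compounds cover only a narrow range of small changes at one place, so it remains open whether a longer chain on the oxygen, such as ethyl or butyl, would also leave the number where it is. An amine or a carboxylic acid at the same position could yet separate from these three, and the present result says nothing about changes elsewhere on the shared core.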